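Urea and amide variants on a shared core

The source may report more compounds than this note shows. Statements on the series, on what has been measured and on what is new or still open speak of the compounds shown alone.

Measured so far:
- compound 1 `COc1cccc(NC(=O)Nc2ccc(Oc3ncnc4[nH]ncc34)cc2)c1` gives 82000 nM in an assay on isolated protein for inhibition of vascular endothelial growth factor receptor 2 (Danio rerio), read by fluorescence and microscopy, with a stated time of 33 h; on this read-out lower numbers stand for stronger inhibition and higher numbers for weaker inhibition
- compound 2 `O=C(Nc1ccc(Oc2ncnc3[nH]ncc23)cc1)c1ccc(Br)cc1` gives 74700 nM in this assay
- compound 3 `O=C(Nc1ccc(Oc2ncnc3[nH]ncc23)cc1)NC1CCCCC1` gives > 100000 nM in this assay

Compound 3 sits at a limit of the assay, not a number (the limit of > 100000 nM in this assay, at which 1 of the 3 values shown sits). It is the only one of the three without a value, and among the three it is the one whose urea nitrogen carries a non-aromatic ring. The steps reaching it are an at least 1.2-fold higher number from compound 1 to compound 3 (0.08 log units; that floor lies within the scatter) and an at least 1.3-fold higher number from compound 2 to compound 3 (0.12 log units; that floor lies within the scatter); both floors lie within the scatter, so nothing beyond the scatter separates the three compounds.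

Compound 4 `O=C(Nc1ccc(Oc2ncnc3[nH]ncc23)cc1)Nc1cccc(F)c1` differs from compound 3 in one place: 3-fluorophenyl in place of cyclohexyl on an amide-type nitrogen. This undoes the kind of change made from compound 1 to compound 3, returning an aryl group to the urea nitrogen. The step that bears on it is an at least 1.2-fold higher number from compound 1 to compound 3 (0.08 log units; that floor lies within the scatter), whose floor is small. Read backwards, it gives no ground to expect a step beyond the scatter in this assay in either direction; a value near that of compound 1 is the plain expectation. Compound 4 is therefore estimated at 80000 nM, between 35000 nM and 200000 nM, which means an expected step of an at least 1.2-fold lower number from compound 3 to compound 4 (0.09 log units; that floor lies within the scatter).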

Compound 4, half-maximal inhibitory concentration: 16600 nM
The estimate for compound 4 lay 4.8-fold (0.68 log units) above the measured number; measured number below the stated range.
By their numbers in this assay, from the lowest: compound 4; then compounds 2 and 1 (each within the scatter of the next). At a limit, above all of these: compound 3.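

With 3-fluorophenyl on the amide-type nitrogen, the series shows its first steps beyond the scatter, and the smallest structural change gives one of them, fluoro in place of methoxy on an aromatic carbon (a 4.9-fold lower number from compound 1 to compound 4 (0.69 log units; beyond the scatter)). The urea is thus not insensitive to what sits on this aromatic ring, and the step from the amide carrying 4-bromophenyl is of similar size (a 4.5-fold lower number from compound 2 to compound 4 (0.65 log units; beyond the scatter)). The aryl group also separates from cyclohexyl beyond the scatter (an at least 6.0-fold lower number from compound 3 to compound 4 (0.77 log units; beyond the scatter)), but compound 3 stands at a limit, so that step is a floor: the limit of > 100000 nM in this assay, at which 1 of the 4 values shown sits.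

From the compounds shown here alone, how chloro, methyl, an amine or a carboxylic acid would read in place of fluoro on that aromatic carbon remains open. Also open, going by these compounds, is whether a plain phenyl on the urea nitrogen would read with compound 4 or with compound 1.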